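The source may report more compounds than this note shows. Statements on the series, on what has been measured and on what is new or still open speak of the compounds shown alone.

In a functional assay on A549 cells (Homo sapiens) for antiproliferative activity, read by MTT assay, with a stated time of 72 h (on this read-out higher numbers stand for weaker inhibition and lower numbers for stronger inhibition), compound 1 `CCOc1ccc(-c2ccc3ncn(-c4cc(OC)c(OC)c(OC)c4)c3c2)cc1` gives 8550 nM, compound 2 `COc1ccc(-c2ccc3ncn(-c4cc(OC)c(OC)c(OC)c4)c3c2)cc1O` gives 200 nM and compound 3 `COc1cc(-n2cnc3ccc(-c4cccc(O)c4)cc32)cc(OC)c1OC` gives 250 nM. Compound 3 thus sits within the scatter of compound 2 and far below compound 1. Compound 4 `COc1cc(-n2cnc3ccc(-c4cccc(F)c4)cc32)cc(OC)c1OC` differs from compound 3 by one change: fluoro in place of hydroxy on an aromatic carbon. Two large steps bear on this, a 43-fold lower number from compound 1 to compound 2 (1.63 log units; beyond the scatter) and a 34-fold lower number from compound 1 to compound 3 (1.53 log units; beyond the scatter), and both end on a ring with hydroxy, while a 1.3-fold higher number from compound 2 to compound 3 (0.10 log units; within the scatter) stays within the scatter. Among the measured compounds shown here, no measured step removes hydroxy alone, so only a moderate rise is expected in this assay, namely a 2.4-fold higher number from compound 3 to compound 4 (0.38 log units; beyond the scatter). The estimated value for compound 4 is 600 nM, within a range of 150 nM to 3000 nM.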

Compound 4, half-maximal inhibitory concentration: 5270 nM
Compound 4: the middle estimate sits 8.8-fold (0.94 log units) below what was measured, and the stated range ends below it.
By their numbers in this assay, from the lowest: compounds 2 and 3 (each within the scatter of the next); then compounds 4 and 1 (each within the scatter of the next).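

In this assay, among the compounds shown here, the earlier compounds linked low numbers only to rings bearing hydroxy, whereas fluoro in place of hydroxy on this aromatic carbon now tests that group alone and gives a large rise (a 21-fold higher number from compound 3 to compound 4 (1.32 log units; beyond the scatter)). The 3-fluorophenyl ring also stands well apart from the 3-hydroxy-4-methoxyphenyl ring (a 26-fold higher number from compound 2 to compound 4 (1.42 log units; beyond the scatter)) but not from the 4-ethoxyphenyl ring (a 1.6-fold lower number from compound 1 to compound 4 (0.21 log units; within the scatter)). Nothing available explains this rise. From the compounds shown here alone, whether an amine or a carboxylic acid on this carbon would keep the low number of compound 3 stays open.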